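The source may report more compounds than this note shows. Statements on the series, on what has been measured and on what is new or still open speak of the compounds shown alone.

Compound 1 `O=C(CSc1nc2c(c(=O)n1-c1ccccc1)SCC2)Nc1ccc(-c2ccccn2)cc1` gives 4 nM in an assay on L cells for inhibition of Protein-serine O-palmitoleoyltransferase porcupine (Mus musculus), read by reporter gene assay, with a stated time of 24 h; on this read-out lower numbers stand for an effect already at smaller amounts and higher numbers for an effect only at larger amounts of compound. Compound 2 `CN(C)c1ccc(NC(=O)CSc2nc3c(c(=O)n2-c2ccccc2)SCC3)cc1` reaches only the limit of > 1000 nM in this assay. Compound 3 `CC(=O)c1ccc(NC(=O)CSc2nc3c(c(=O)n2-c2ccccc2)SCC3)cc1` likewise reaches only the limit of > 1000 nM in this assay, so compound 3 stands at the limit shared by two of the three values (the limit of > 1000 nM in this assay, at which 2 of the 3 values shown sit). The steps of an at least 250-fold higher number from compound 1 to compound 2 (2.39 log units; beyond the scatter) and an at least 250-fold higher number from compound 1 to compound 3 (2.39 log units; beyond the scatter) are both large, while a step that the two limits leave unreadable from compound 2 to compound 3 cannot be read. Compound 4 `O=C(CSc1nc2c(c(=O)n1-c1ccccc1)SCC2)Nc1ccc(-c2ccccc2)cc1` carries the change (phenyl in place of acetyl on an aromatic carbon). Only compound 1 with 4 nM gives a number, and its pyridin-2-yl is, like the entering phenyl, an aromatic ring. A large fall in number is therefore expected, an at least 33-fold lower number from compound 3 to compound 4 (1.52 log units; beyond the scatter), though from a limit its size stays uncertain. Compound 4 is estimated at 30 nM, between 5 nM and 300 nM.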

Compound 4, half-maximal effective concentration: 0.75 nM
Estimate against measurement, compound 4: 40-fold (1.60 log units) above; measured number outside the range, below it.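

In this assay, the pyridin-2-yl of compound 1 proves dispensable for a low number: phenyl, an aromatic ring of carbon only, gives a 5.3-fold lower number from compound 1 to compound 4 (0.73 log units; beyond the scatter). Against the two groups without a ring, the steps are large: an at least 1300-fold lower number from compound 3 to compound 4 (3.12 log units; beyond the scatter) and an at least 1300-fold lower number from compound 2 to compound 4 (3.12 log units; beyond the scatter). Both of these steps start from a limit, so their true size cannot be read: the limit of > 1000 nM in this assay, at which 2 of the 4 values shown sit.

As far as these compounds go, whether a saturated ring such as cyclohexyl or morpholine would serve at this place stays open. So does the effect of a fluorine or a methoxy group on the entering phenyl.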